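Swapping the trifluoromethylphenyl position on a thiazole acylhydrazone

This account rests on a few compounds, and the source may have more. Where it says the series, first, only, none or still open, it means among the compounds named here.

Measured compounds in a functional assay on HepG2 cells (Homo sapiens) for inhibition, read by MTT assay, with a stated time of 72 h; a lower number here means a stronger inhibitor, a higher number a weaker inhibitor:
compound 1, `CN(C(=O)NC(=O)c1c(F)cccc1F)c1nc(C(F)(F)F)c(C(=O)N/N=C/c2cccc(C(F)(F)F)c2)s1`, gives 27.9 ug/mL
compound 2, `CN(C(=O)NC(=O)c1ccccc1F)c1nc(C(F)(F)F)c(C(=O)N/N=C/c2ccccc2C(F)(F)F)s1`, gives 5.39 ug/mL
compound 3, `CN(C(=O)NC(=O)c1c(F)cccc1F)c1nc(C(F)(F)F)c(C(=O)N/N=C/c2ccccc2C(F)(F)F)s1`, gives 26.1 ug/mL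

Compound 2 has the lowest of the three numbers in this assay; its nearest neighbour, compound 3, lies beyond the scatter from it, as does compound 1. The difference between compound 2 and compound 3 is hydrogen in place of fluoro on an aromatic carbon, and that step reads a 4.8-fold higher number from compound 2 to compound 3 (0.69 log units; beyond the scatter). From compound 3 to compound 1 the change is 3-(trifluoromethyl)phenyl in place of 2-(trifluoromethyl)phenyl on a carbon with a double bond to nitrogen, and here the step is a 1.1-fold higher number from compound 3 to compound 1 (0.03 log units; within the scatter), so the two numbers fall within the scatter of each other.

Compound 4, `CN(C(=O)NC(=O)c1ccccc1F)c1nc(C(F)(F)F)c(C(=O)N/N=C/c2cccc(C(F)(F)F)c2)s1`, has not yet been measured. It differs from compound 2 by 3-(trifluoromethyl)phenyl in place of 2-(trifluoromethyl)phenyl on a carbon with a double bond to nitrogen, which is the same change as that from compound 3 to compound 1, at the same place on the shared core; the cores of compound 2 and compound 4 differ from those of compound 3 and compound 1 only by hydrogen in place of fluoro on an aromatic carbon. Because a 1.1-fold higher number from compound 3 to compound 1 (0.03 log units; within the scatter) was within the scatter, compound 4 is expected to stay close to compound 2, with an expected step of a 1.1-fold higher number from compound 2 to compound 4 (0.05 log units; within the scatter). The estimate for compound 4 in this assay is therefore 6 ug/mL, between 3 ug/mL and 13 ug/mL.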

Compound 4, half-maximal inhibitory concentration: 20.3 ug/mL
For compound 4 the middle estimate is 3.4-fold (0.53 log units) below the measured one; measured number outside the range, above it.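

In this assay, the change from 2-(trifluoromethyl)phenyl to 3-(trifluoromethyl)phenyl gives a 3.8-fold higher number from compound 2 to compound 4 (0.58 log units; beyond the scatter), so a change that stayed within the scatter on the core of compound 3 did not carry over unchanged to the core of compound 2: the same change on two cores in this assay, a 1.1-fold higher number (0.03 log units; within the scatter) from compound 3 to compound 1 and a 3.8-fold higher number (0.58 log units; beyond the scatter) from compound 2 to compound 4, 3.5-fold (0.55 log units) apart, beyond the scatter of two such steps

The fluoro change likewise depends on its partner, with hydrogen in place of fluoro giving a 1.4-fold lower number from compound 1 to compound 4 (0.14 log units; within the scatter), a step within the scatter, whereas the same difference between compound 2 and compound 3 lies beyond it: the same change on two cores in this assay, a 4.8-fold higher number (0.69 log units; beyond the scatter) from compound 2 to compound 3 and a 1.4-fold higher number (0.14 log units; within the scatter) from compound 4 to compound 1, 3.5-fold (0.55 log units) apart, beyond the scatter of two such steps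

These four compounds therefore show that the two changes do not add independently here, but they do not show the mechanism behind this, nor how either change would behave on any other core.

From the compounds shown here alone, whether the same dependence holds with a nitrile or a methoxy group in place of trifluoromethyl on the phenyl ring remains open. Also open, going by these compounds, is whether a chloro group in place of fluoro would behave in the same way.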